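A few compounds are considered here, and "the series" means these few. Any claim that something is new, unique, unknown or untested is made for them only; others in the source may bear on it.

Compounds measured so far in a functional assay on CHO cells for antagonist activity at sphingosine 1-phosphate receptor 2 (Homo sapiens), read by GTPgammaS binding; a lower number here means a stronger inhibitor, a higher number a weaker inhibitor:
compound 1, `O=C(O)Cn1nc(CC(=O)Nc2ccc(OC(F)(F)F)c(Cl)c2)c2ccccc2c1=O`, 754 nM
compound 2, `C[C@@H](C(=O)O)c1nn(Cc2cn3cc(OCC4CC4)c(Cl)cc3n2)c2ccccc2c1=O`, 253 nM
compound 3, `CCC(C(=O)O)c1nn(Cc2cn3cc(OCC4CC4)c(Cl)cc3n2)c2ccccc2c1=O`, 43 nM

Compound 3 gives the lowest number of the three. Its nearest neighbour is compound 2, which sits higher by a 5.9-fold lower number from compound 2 to compound 3 (0.77 log units; beyond the scatter), a step beyond the scatter; compound 1 lies furthest away with 754 nM, whereas compound 3 gives 43 nM. Compound 4, `O=C(O)C1(c2nn(Cc3cn4cc(OCC5CC5)c(Cl)cc4n3)c3ccccc3c2=O)CC1`, is not yet measured. It differs from compound 3 in one place: 1-carboxycyclopropyl in place of 1-carboxypropyl on an aromatic carbon. The group that leaves and the group that enters have the same count of heavy atoms, donors and acceptors; only the cyclopropyl ring is new. Among the measured compounds shown here, the single step that bears on this position, a 5.9-fold lower number from compound 2 to compound 3 (0.77 log units; beyond the scatter), shows that the 1-carboxyethyl to 1-carboxypropyl change lowered the number substantially, so this position tolerates and rewards a larger carboxyalkyl group. For the measured compounds named here, no measured step shows the effect of closing such a group into a three-membered ring, so the expectation for compound 4 rests on the similar size of the two groups. Compound 4 is expected to stay near compound 3, with a step of a 1.6-fold higher number from compound 3 to compound 4 (0.21 log units; within the scatter) in this assay, and an estimated value of 70 nM, in the range 20 nM to 250 nM.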

Compound 4, half-maximal inhibitory concentration: 82 nM
For compound 4 the middle estimate is 1.2-fold (0.07 log units) below the measured one, within the range that was stated.
By their numbers in this assay, from the lowest: compounds 3 and 4 (each within the scatter of the next); then compound 2; then compound 1.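

In this assay, closing the chain into a three-membered ring gives a step within the scatter (a 1.9-fold higher number from compound 3 to compound 4 (0.28 log units; within the scatter)), so 1-carboxycyclopropyl and 1-carboxypropyl cannot be told apart at this position. Against 1-carboxyethyl the ring gives a step beyond the scatter (a 3.1-fold lower number from compound 2 to compound 4 (0.49 log units; beyond the scatter)), so the lower number seen with 1-carboxypropyl does not depend on an open chain. Nothing available explains why these groups read as they do.

The compounds shown leave open whether a larger ring, as in 1-carboxycyclobutyl, or a longer chain, as in 1-carboxybutyl, would keep or lower the number. They also leave open whether the carboxylic acid itself is needed here, or whether a primary amide or a tetrazole could stand in its place.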